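Swapping bromo for fluoro: what compound 4 may show

The source may report more compounds than this note shows. Statements on the series, on what has been measured and on what is new or still open speak of the compounds shown alone.

- compound 1 `COc1ccc2[nH]cc(CCCN3CCN(C(=O)CN4CCN(C(=O)c5ccc(Cl)cc5)CC4)CC3)c2c1` gives 117000 nM
- compound 2 `COc1ccc2[nH]cc(CCCN3CCN(C(=O)CN4CCN(C(=O)c5ccc(C)cc5)CC4)CC3)c2c1` gives 147000 nM
- compound 3 `COc1ccc2[nH]cc(CCCN3CCN(C(=O)CN4CCN(C(=O)c5cccc(Br)c5)CC4)CC3)c2c1` gives 57000 nM
- compound 4 `COc1ccc2[nH]cc(CCCN3CCN(C(=O)CN4CCN(C(=O)c5cccc(F)c5)CC4)CC3)c2c1` is not yet measured

All these numbers come from an ADME assay on HEK293 cells (Homo sapiens) for cytotoxicity, read by MTT assay, with a stated time of 72 h (on this read-out higher numbers stand for weaker inhibition and lower numbers for stronger inhibition), and compound 3 (57000 nM) has the lowest of the three. Compound 4 differs from compound 3 in one place (fluoro in place of bromo on an aromatic carbon), with fluoro in place of bromo on an aromatic carbon. Going by the values given here, no measured step makes this exact swap, and no fluoro compound has a value yet. The nearest guide is methyl in place of chloro, which gave a 1.3-fold higher number from compound 1 to compound 2 (0.10 log units; within the scatter) and stayed small. Two other changes gave a 2.1-fold lower number from compound 1 to compound 3 (0.31 log units; beyond the scatter) and a 2.6-fold lower number from compound 2 to compound 3 (0.41 log units; beyond the scatter) and both are modest, but each also alters where the group sits on the ring. With compound 3 at the low end (57000 nM), a slightly higher number is expected. The expected change is a 1.6-fold higher number from compound 3 to compound 4 (0.20 log units; within the scatter) and it would be a small one. Compound 4 is estimated at 90000 nM with 45000 nM to 180000 nM as the expected span.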

Compound 4, half-maximal inhibitory concentration: > 200000 nM
Compound 4: a limit, no number; the forecaster's own chance of this, stated with the estimate: 10%; at least 2.2-fold (0.34 log units) between middle value and limit.
By their numbers in this assay, from the lowest: compound 3; then compounds 1 and 2 (each within the scatter of the next). At a limit, above all of these: compound 4.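

In this assay compound 4 stands only at a limit, not a number: the limit of > 200000 nM in this assay, at which 1 of the 4 values shown sits. On this ring, exchanging bromo for fluoro replaces one heavy atom with one other and gives an at least 3.5-fold higher number from compound 3 to compound 4 (0.54 log units; beyond the scatter), so a change this small at this position can move the read-out beyond the scatter, whereas the earlier methyl for chloro step stayed within it. The comparisons with the other two compounds are looser, giving an at least 1.3-fold higher number from compound 2 to compound 4 (0.13 log units; that floor lies within the scatter) and an at least 1.7-fold higher number from compound 1 to compound 4 (0.23 log units; that floor lies within the scatter), and those steps also move the group on the ring.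

On these data alone, it remains open whether chloro, methyl or an amine at this same position would read closer to compound 3 or to compound 4. As far as these compounds go, how far compound 4 really lies from compound 3 also remains open.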